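The source may hold more compounds than are shown below. What is called first, only, known or untested is meant among the compounds shown, and "the series" means these compounds.

The compounds here share one core, seen in compound 2 `O=C1N(Cc2cccc(COc3ccc(-c4ccc(Cl)cc4)cc3)c2)CCN1c1ccncc1`, and all were tested in an ADME assay on cells (Homo sapiens) for cytotoxicity; a higher number here means that more compound is tolerated, a lower number that less compound is tolerated. For compound 2 the reading is a limit of the assay, > 6250 nM, that is the limit of > 6250 nM in this assay, at which 1 of the 3 values shown sits. Compound 1 `CCc1nc(-c2ccc(OCCC(C)CCN3CCN(c4ccncc4)C3=O)cc2)no1` also reaches only a limit, > 25000 nM. Compound 3 `O=C1N(Cc2ccc(COc3ccc(-c4ccc(Cl)cc4)cc3)cc2)CCN1c1ccncc1` likewise gives only a limit, > 1250 nM. So compound 2 stands among three readings that are all limits, without a firm number. Compound 4 `Cc1cc(COc2ccc(-c3ccc(Cl)cc3)cc2)cc(CN2CCN(c3ccncc3)C2=O)c1` differs from compound 2 by one change, (methyl in place of hydrogen on an aromatic carbon), methyl in place of hydrogen on an aromatic carbon. Among the compounds with values here, no step between measured compounds guides the size; the change is expected to bring nothing beyond the scatter, a step that the limit leaves unreadable from compound 2 to compound 4. Compound 4 is therefore estimated at 10000 nM, between 3000 nM and 30000 nM, most likely again reported only as a limit.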

Compound 4, half-maximal cytotoxic concentration: > 25000 nM
Compound 4: no number, only a limit; the forecaster's own chance of this, stated with the estimate: 70%; middle value at least 2.5-fold (0.39 log units) from the limit.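

Compound 2 and compound 4 each give only a limit, and no step can be read between them. All four compounds shown remain limits in this assay, leaving open the concentration at which any of them reaches half-maximal cytotoxicity.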